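The source may hold more compounds than are shown below. What is called first, only, known or untested is meant among the compounds shown, and "the series" means these compounds.

Working notes on the series. Compound 1 `C/C=C/C(=O)Nc1cc2c(N3CCCc4ccccc43)ncnc2cc1OC` carries the shared core with an unsubstituted crotonamide chain, and in a functional assay on MCF7 cells (Homo sapiens) for antiproliferative activity, read by MTT assay, with a stated time of 72 h (a higher number here means a weaker inhibitor, a lower number a stronger inhibitor), compound 1 gives 12700 nM. Compound 2 `COc1cc2ncnc(N3CCCc4ccccc43)c2cc1NC(=O)/C=C/CN1CCCCC1` differs in one place, and in this assay compound 2 gives 3930 nM. Going by the values given here, the step of a 3.2-fold lower number from compound 1 to compound 2 (0.51 log units; beyond the scatter) is the only measured step so far, and it puts compound 2 at the lower of the two numbers, with compound 1 as its nearest neighbour, separated by a gap that lies beyond the scatter.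

Compound 3 `COc1cc2ncnc(N3CCCc4ccccc43)c2cc1NC(=O)/C=C/CN1CCN(C)CC1` is not yet measured. The change from compound 2 to compound 3 is 4-methylpiperazin-1-yl in place of piperidin-1-yl on a saturated chain carbon bound to a double-bonded chain carbon. Among the compounds with values here, no measured step bears directly on this exchange: the one measured step concerns the presence of a ring amine on the chain, not the identity of that ring. The piperidin-1-yl and 4-methylpiperazin-1-yl groups differ by one ring nitrogen and one methyl, so no step beyond the scatter is expected in this assay in either direction. The expected step is a 1.1-fold lower number from compound 2 to compound 3 (0.05 log units; within the scatter). Compound 3 is therefore estimated at 3500 nM, with a range from 1500 nM to 9000 nM.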

Compound 3, half-maximal inhibitory concentration: 8560 nM
For compound 3 the middle estimate is 2.4-fold (0.39 log units) below the measured one; the measured number falls inside the stated range.
By their numbers in this assay, from the lowest: compound 2; then compounds 3 and 1 (each within the scatter of the next).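

In this assay, the identity of the ring on the saturated chain carbon bound to a double-bonded chain carbon now proves to matter: 4-methylpiperazin-1-yl in place of piperidin-1-yl gives a 2.2-fold higher number from compound 2 to compound 3 (0.34 log units; beyond the scatter), a modest step but one beyond the scatter. The gain seen with piperidin-1-yl does not carry over to the other ring, since 4-methylpiperazin-1-yl in place of hydrogen gives only a 1.5-fold lower number from compound 1 to compound 3 (0.17 log units; within the scatter), so among these three compounds a ring amine on the chain is not enough by itself to separate a compound from the unsubstituted crotonamide of compound 1. No measurement at hand accounts for the difference between the two rings.

The compounds shown leave open whether the step follows the second ring nitrogen or its methyl: piperazin-1-yl, which lacks the methyl, and morpholin-4-yl, which has an oxygen in that ring, would help separate the two. Also open, as far as these compounds go, is whether a ring is needed at all on this carbon, a question that an open-chain amine such as dimethylamino would address.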